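Swapping a Furan for a Trifluoromethylphenyl Amide

A few compounds are considered here, and "the series" means these few. Any claim that something is new, unique, unknown or untested is made for them only; others in the source may bear on it.

In a functional assay on A2780 cells (Homo sapiens) for antiproliferative activity, read by fluorescence, with a stated time of 72 h (on this read-out higher numbers stand for weaker inhibition and lower numbers for stronger inhibition), compound 1 `CC(C)(C)C(=O)N1Cc2c(NC(=O)c3ccncc3)n[nH]c2C1(C)C` gives 110 nM. Among the measured compounds shown here, compound 2 `CN1CCC(C(=O)Nc2n[nH]c3c2CN(C(=O)C(C)(C)C)C3(C)C)CC1` gives 350 nM in this assay, and the one measured step, a 3.2-fold higher number from compound 1 to compound 2 (0.50 log units; beyond the scatter), describes that exchange on a carbonyl carbon. Compound 3 `CN1CCC(C(=O)N2Cc3c(NC(=O)c4ccco4)n[nH]c3C2(C)C)CC1` carries a 1-methylpiperidin-4-yl group on one carbonyl carbon and a furan-2-yl group on another. For compound 3 in this assay only a limit was obtained, > 5000 nM. This is the limit of > 5000 nM in this assay, at which 1 of the 3 values shown sits, so compound 3 stands at the weak end of what has been seen, without an exact figure.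

Compound 4 `CN1CCC(C(=O)N2Cc3c(NC(=O)c4ccc(C(F)(F)F)cc4)n[nH]c3C2(C)C)CC1` differs from compound 3 in a single place: 4-(trifluoromethyl)phenyl in place of furan-2-yl on a carbonyl carbon. For the measured compounds named here, no measured step concerns this exchange; the only step available, a 3.2-fold higher number from compound 1 to compound 2 (0.50 log units; beyond the scatter), involves other groups, so it gives no direct guidance on the size or direction of what to expect. With compound 3 known only as a limit, any forecast for compound 4 must be wide. Compound 4 is estimated to give 3000 nM in this assay, with a range from 500 nM to 20000 nM. The step of an at least 1.6-fold lower number from compound 3 to compound 4 (0.22 log units; that floor lies within the scatter) is thus expected to be modest at best, and it may well fall within the scatter, with a real chance that compound 4 again returns only a limit.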

Compound 4, half-maximal inhibitory concentration: 60 nM
The estimate for compound 4 lay 50-fold (1.70 log units) above the measured number, and the stated range ends above it.
By their numbers in this assay, from the lowest: compounds 4 and 1 (each within the scatter of the next); then compound 2. At a limit, above all of these: compound 3.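

The carbonyl carbon whose other neighbour is an amide-type nitrogen turns out to be highly sensitive to what it carries: with the rest of the molecule unchanged, 4-(trifluoromethyl)phenyl in place of furan-2-yl gives an at least 83-fold lower number from compound 3 to compound 4 (1.92 log units; beyond the scatter) in this assay. Among the compounds shown here, until this result the only step that could be read was a 3.2-fold higher number from compound 1 to compound 2 (0.50 log units; beyond the scatter), a modest one, so the earlier compounds gave no sign that a single exchange of this kind could move the number so far. Compound 3 is known only as a limit, so the new step gives a minimum size and not an exact one: the limit of > 5000 nM in this assay, at which 1 of the 4 values shown sits.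

The two groups differ at once in ring size, in the hetero atom and in the trifluoromethyl group, and these numbers cannot say which of those differences carries the gain. A plain phenyl group on this carbonyl carbon, or a phenyl ring carrying a nitrile instead of the trifluoromethyl group, would help separate the contribution of the six-membered ring from that of the group attached to it.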